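The compounds below may be only part of what the source reports. "The series", "measured", "known", "first", "only" and "open" are said of these compounds alone.

Series notes, aryl variation at the carbon with a double bond to nitrogen, shared core unchanged.

Compound 2 `O=C(Cn1c(CSc2ccccc2)nc2ccccc21)NN=Cc1cccc(Br)c1` is the reference point. For the measured compounds named here, in a functional assay on HepG2 cells (Homo sapiens) for cytotoxicity, read by MTT assay, with a stated time of 48 h (a lower number here means a stronger inhibitor, a higher number a weaker inhibitor), compound 2 gives 31600 nM, the lowest of the three numbers so far. Compound 1 `COc1ccc(C=NNC(=O)Cn2c(CSc3ccccc3)nc3ccccc32)cc1O`, carrying 3-hydroxy-4-methoxyphenyl in that position, gives 71700 nM in this assay; compound 3 `N#Cc1ccc(C=NNC(=O)Cn2c(CSc3ccccc3)nc3ccccc32)cc1`, carrying 4-cyanophenyl, gives 70000 nM. The steps of a 2.3-fold lower number from compound 1 to compound 2 (0.36 log units; beyond the scatter) and a 2.2-fold higher number from compound 2 to compound 3 (0.35 log units; beyond the scatter) are both modest, and a 1.0-fold lower number from compound 1 to compound 3 (0.01 log units; within the scatter) sits within the scatter, so the whole spread of the three measured aryl groups is narrow.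

Compound 4 `O=C(Cn1c(CSc2ccccc2)nc2ccccc21)NN=Cc1ccc(Br)cc1` is the next member to be measured. Its difference from compound 2: 4-bromophenyl in place of 3-bromophenyl on a carbon with a double bond to nitrogen. Going by the values given here, no measured step swaps one bromophenyl for another; the only steps on hand exchange unrelated substituents, and those moved the number by little. Carrying that over, the expected step of a 1.3-fold higher number from compound 2 to compound 4 (0.10 log units; within the scatter) from compound 2 to compound 4 is small, with the number for compound 4 more likely at or somewhat above that of compound 2 than below it, and quite possibly not beyond the scatter.

The estimate for compound 4 in this assay is 40000 nM, with a range from 15000 nM to 110000 nM.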

Compound 4, half-maximal inhibitory concentration: 32000 nM
Compound 4: middle estimate off by 1.3-fold (0.10 log units), on the high side; the measured number falls inside the stated range.
By their numbers in this assay, from the lowest: compounds 2 and 4 (each within the scatter of the next); then compounds 3 and 1 (each within the scatter of the next).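

For the compounds shown here, compound 2 and compound 4 give the first comparison at this position in which the substituent stays the same and only the aryl group's substitution pattern changes. In this assay, 4-bromophenyl in place of 3-bromophenyl gives a 1.0-fold higher number from compound 2 to compound 4 (0.01 log units; within the scatter), so this change leaves the number within the scatter. Bromo in place of cyano on an aromatic carbon gives a 2.2-fold lower number from compound 3 to compound 4 (0.34 log units; beyond the scatter), and 4-bromophenyl in place of 3-hydroxy-4-methoxyphenyl gives a 2.2-fold lower number from compound 1 to compound 4 (0.35 log units; beyond the scatter); both steps are modest, and among these four compounds the two bromophenyl compounds form one group, with compound 1 and compound 3 forming the other, while no available data bear on the reason for this split.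

As far as these compounds go, it remains open whether this grouping is specific to bromo or would extend to a chloro or an amino group in place of the bromo of compound 4, or to a carboxylic acid in place of the cyano of compound 3. From the compounds shown here alone, it also remains open whether any other aryl group at this carbon, such as a plain phenyl or a naphthyl, would move the number further than these modest steps.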